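From 3-Chlorophenyl to Methyl on an Aromatic Oxygen

The compounds below may be only part of what the source reports. "The series", "measured", "known", "first", "only" and "open" are said of these compounds alone.

The measured compounds:
- compound 1 `CN1C[C@H]2C=C(c3cccnc3)C[C@H](C2)C1` gives 2.1 nM in an in vitro assay on SH-EP1 cells for displacement of a labelled ligand from Neuronal acetylcholine receptor; alpha4/beta2 (Homo sapiens); on this read-out higher numbers stand for weaker inhibition and lower numbers for stronger inhibition
- compound 2 `Clc1cccc(Oc2cncc(C3=CC4CNCC(C3)C4)c2)c1` gives 1 nM in this assay
- compound 3 `C1=C(c2ccc(-c3ccccc3)nc2)CC2CNCC1C2` gives 105 nM in this assay

Among these three, compound 2 has the lowest number, which on this read-out means the strongest inhibition. Compound 1 stands next to it, with a number somewhat higher, a gap that lies beyond the usual scatter. Compound 3 stands far away, with a number that is higher, a gap that also lies beyond the usual scatter.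

The unmeasured compound 4 `COc1cncc(C2=CC3CNCC(C2)C3)c1` keeps the whole framework of compound 2 and differs in one place: methyl in place of 3-chlorophenyl on an oxygen on an aromatic ring. The large ring-bearing group is thus traded for the smallest possible substituent, while the oxygen link to the aromatic ring stays where it was.

Among the measured compounds shown here, no step between two measured compounds mirrors this swap, so there is nothing direct to lean on. Compound 1, which carries no substituent at all on its aromatic ring beyond the shared core, still reaches 2.1 nM, which suggests the framework alone already binds tightly. Compound 4 is therefore expected to remain a strong inhibitor, though with a modest loss: the step from compound 2 to compound 4 is estimated at a 3.0-fold higher number from compound 2 to compound 4 (0.48 log units; beyond the scatter). The value for compound 4 in this assay is expected to be about 3 nM, within a range from 0.8 nM to 12 nM.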

Compound 4, inhibition constant: 0.3 nM
Estimate against measurement, compound 4: 10-fold (1.00 log units) above, outside the stated range (below it).
By their numbers in this assay, from the lowest: compound 4; then compound 2; then compound 1; then compound 3.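

In this assay the step to the far smaller group brings no loss: methyl in place of 3-chlorophenyl on an oxygen on an aromatic ring gives a 3.3-fold lower number from compound 2 to compound 4 (0.52 log units; beyond the scatter), which means stronger inhibition, by a modest step that lies beyond the usual scatter. So this position does not need the 3-chlorophenyl group to reach strong inhibition, even though 7 heavy atoms and an aromatic ring leave and only a single carbon enters. The compounds shown offer no measurement that accounts for this gain, and it rests on this one pair of compounds in this one assay.

From the compounds shown here alone, it remains open how groups of intermediate size would behave on the same oxygen, for example an ethyl or propyl chain, or a phenyl ring without its chlorine, and whether the trend from 3-chlorophenyl to methyl runs smoothly or depends on something particular to these two groups. The role of the oxygen itself also remains open, as the compounds shown do not reveal what an amine in its place, or a hydroxyl group at the same spot on the aromatic ring, would do.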